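Cytotoxicity in HeLa cells across three biaryl analogues

A few compounds are considered here, and "the series" means these few. Any claim that something is new, unique, unknown or untested is made for them only; others in the source may bear on it.

Compound 2 `COc1cc(CC(O)c2ccc(-c3ccccc3CO)cc2)c([N+](=O)[O-])cc1OC`: 24000 nM
Compound 1 `COc1cc(CC(O)c2ccc(-c3cccc(C#N)c3)cc2)c([N+](=O)[O-])cc1OC`: 5200 nM

In an ADME assay on HeLa Rh cells (Homo sapiens) for cytotoxicity, read by microscopy (on this read-out higher numbers stand for lower toxicity in this test and lower numbers for higher toxicity in this test), compound 2 holds the higher of the two measured numbers; it stands apart from compound 1 by a 4.6-fold higher number from compound 1 to compound 2 (0.66 log units; beyond the scatter). Compound 3 `COc1cc(CC(O)c2ccc(-c3cccnc3)cc2)c([N+](=O)[O-])cc1OC` differs from compound 2 by pyridin-3-yl in place of 2-(hydroxymethyl)phenyl on an aromatic carbon. Going by the values given here, no measured step covers a pyridin-3-yl group, so the only guide is that swapping the aryl substituent moved the number from compound 1 to compound 2 by a modest amount. A step of similar size downward from compound 2 to compound 3 is expected, a 2.0-fold lower number from compound 2 to compound 3 (0.30 log units; within the scatter), giving an estimate for compound 3 of 12000 nM, within 4000 nM to 35000 nM.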

Compound 3, half-maximal cytotoxic concentration: > 263000 nM
Compound 3 gave a limit, no number (the forecaster's own chance of this, stated with the estimate: 10%); at least 21-fold (1.34 log units) between middle value and limit.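

Compound 3 gives a limit in this assay, not a number: the limit of > 263000 nM in this assay, at which 1 of the 3 values shown sits.

With pyridin-3-yl on this aromatic carbon, para to a large group, the change brings an at least 10-fold higher number from compound 2 to compound 3 (1.03 log units; beyond the scatter) and an at least 50-fold higher number from compound 1 to compound 3 (1.70 log units; beyond the scatter). The aryl group at this position can therefore move the read-out much further than a 4.6-fold higher number from compound 1 to compound 2 (0.66 log units; beyond the scatter) suggested.

Going by these compounds, whether an unsubstituted phenyl or a pyridin-4-yl group would behave like pyridin-3-yl remains open. So does how far compound 3 really lies beyond its limit.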